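The source may hold more compounds than are shown below. What is called first, only, known or untested is meant among the compounds shown, and "the series" means these compounds.

Compound 2, with the structure `Cc1c(OCCCCOc2ccc(C(=O)O)cc2Cl)ccc(C(=O)CC2CCCC2)c1O`, is one of three compounds tested in an assay on HEK293 cells for positive allosteric modulation of metabotropic glutamate receptor 2 (Rattus norvegicus), read by thallium flux, with a stated time of 2.5 min (on this read-out higher numbers stand for larger maximal responses and lower numbers for smaller maximal responses), and there compound 2 gives 82.2%. Compound 1, `COc1cc(C(=O)O)ccc1OCCCCOc1ccc(C(=O)CC(C)C)c(O)c1C`, gives 85.7% in this assay, which puts compound 2 second highest of the three, with compound 1 within the usual scatter of it. Compound 3, `Cc1c(OCCCCOc2cccc(C(=O)O)c2)ccc(C(=O)CC(C)C)c1C`, gives 12.1% in this assay, far below compound 2 and beyond the scatter.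

Compound 4, `Cc1c(OCCCCOc2ccccc2C(=O)O)ccc(C(=O)CC2CCCC2)c1O`, has not yet been measured. It differs from compound 2 in one place: 2-carboxyphenyl in place of 4-carboxy-2-chlorophenyl on an oxygen on a saturated carbon. The group that leaves carries both a carboxylic acid and a chlorine; the group that enters carries only the carboxylic acid, and that acid now sits at the 2-position of the phenyl rather than the 4-position.

Among the measured compounds shown here, no step between measured compounds isolates this change. For the measured compounds named here, the only measured compound whose acid is not at the 4-position is compound 3, which also differs from compound 2 in its core, so it is not a clean guide. Even so, compound 3 is expected to point the way, and a downward step from compound 2 to compound 4 of a number 37.2 percentage points lower from compound 2 to compound 4 (beyond the scatter) in this assay is expected. Compound 4 is therefore estimated at 45%, most likely between 15% and 80%.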

Compound 4, largest response reached (reported as percent of maximum), in percent of the reference or control that the assay uses: 98.8%
For compound 4 the middle estimate is 53.8 percentage points below the measured one; measured number outside the range, above it.
By their numbers in this assay, from the lowest: compound 3; then compounds 2 and 1 (each within the scatter of the next); then compound 4.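

In this assay, putting 2-carboxyphenyl in place of 4-carboxy-2-chlorophenyl on this oxygen gives a number 16.6 percentage points higher from compound 2 to compound 4 (beyond the scatter). On the core shared by these two compounds, a large maximal response therefore does not depend on the chlorine or on having the carboxylic acid at the 4-position, and the group with fewer heavy atoms gives the larger response. Among the compounds shown here, the data offer no explanation for this rise, and the single step combines two changes, the loss of the chlorine and the move of the acid, so it cannot be divided between them.

The compounds shown leave open how much of the step belongs to each change, which a 4-carboxyphenyl group without chlorine or a chlorine-bearing 2-carboxyphenyl group on this same core could help to separate. They also leave open whether the carboxylic acid itself can be replaced at this end of the molecule, for example by a tetrazole or a primary amide, and whether a maximal response of this size would survive such an exchange.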